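The source may hold more compounds than are shown below. What is called first, only, known or untested is meant among the compounds shown, and "the series" means these compounds.

Going by the values given here, in a functional assay on HepG2 cells (Homo sapiens), read by MTT assay, with a stated time of 48 h (on this read-out higher numbers stand for weaker inhibition and lower numbers for stronger inhibition), compound 3 `CCN(CC)CCCNC(=O)c1ccc(C(CC)(CC)c2ccc(OCC(=O)C(C)(C)C)c(C)c2)n1CC` gives 180 nM, the lowest number so far. Compound 2 `CCn1c(C(=O)NCCCN(C)C)ccc1C(CC)(CC)c1ccc(OCC(=O)C(C)(C)C)c(C)c1` gives 960 nM and compound 1 `CCn1c(C(=O)NCCN(C)C)ccc1C(CC)(CC)c1ccc(OCC(=O)C(C)(C)C)c(C)c1` gives 2300 nM. Compound 4 `CCn1c(C(=O)N(C)CC(=O)O)ccc1C(CC)(CC)c1ccc(OCC(=O)C(C)(C)C)c(C)c1` changes the group on the carbonyl carbon: (carboxymethyl)(methyl)amino in place of (3-(diethylamino)propyl)amino on a carbonyl carbon. The measured steps alter only the amine end of the chain: a 2.4-fold lower number from compound 1 to compound 2 (0.38 log units; beyond the scatter) and a 5.3-fold lower number from compound 2 to compound 3 (0.73 log units; beyond the scatter) are modest, while a 13-fold lower number from compound 1 to compound 3 (1.11 log units; beyond the scatter) is large. Among the compounds with values here, no measured compound has a carboxymethyl group or lacks the amine chain, so these steps are only a loose guide. Since this replacement removes the whole chain varied in a 13-fold lower number from compound 1 to compound 3 (1.11 log units; beyond the scatter), a large rise in the number is expected, estimated as a 56-fold higher number from compound 3 to compound 4 (1.74 log units; beyond the scatter). Compound 4 is estimated at 10000 nM, with an expected range from 2000 nM to 50000 nM.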

Compound 4, half-maximal inhibitory concentration: 25200 nM
Compound 4: middle estimate off by 2.5-fold (0.40 log units), on the low side; measured number inside the range.
By their numbers in this assay, from the lowest: compound 3; then compound 2; then compound 1; then compound 4.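

In this assay, (carboxymethyl)(methyl)amino on the carbonyl carbon gives a large rise in the number against each amine chain: a 140-fold higher number from compound 3 to compound 4 (2.15 log units; beyond the scatter) and a 26-fold higher number from compound 2 to compound 4 (1.42 log units; beyond the scatter) and an 11-fold higher number from compound 1 to compound 4 (1.04 log units; beyond the scatter). Thus this position responds not only to the amine end of the chain but also to replacing the whole group. No evidence here gives a reason for the rise.

The compounds shown leave open whether the rise follows from losing the amine, gaining the carboxylic acid, or adding the methyl on the amide nitrogen. A diethylamino chain on that methylated nitrogen, or a longer chain ending in a carboxylic acid, would separate these.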